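A six-membered ring rearranged on the shared core

This account rests on a few compounds, and the source may have more. Where it says the series, first, only, none or still open, it means among the compounds named here.

Within the data shown here, in an assay on cells for inhibition of cytochrome P450 11B2, mitochondrial (Homo sapiens), read by HPLC, with a stated time of 90 min (on this read-out lower numbers stand for stronger inhibition and higher numbers for weaker inhibition), compound 2 `Fc1ccc2nc(-c3cncnc3)n(C3CC3)c2c1` gives 40 nM, the only number among the two values shown. Compound 1 `Fc1ccc2nc(-c3cnco3)n(C3CC3)c2c1` gives only a limit there, > 10000 nM, as recorded in the limit of > 10000 nM in this assay, at which 1 of the 2 values shown sits. Among the measured compounds shown here, the single measured step is an at least 250-fold lower number from compound 1 to compound 2 (2.39 log units; beyond the scatter). Compound 3 `Fc1ccc2nc(-c3ccnnc3)n(C3CC3)c2c1` differs from compound 2 by pyridazin-4-yl in place of pyrimidin-5-yl on an aromatic carbon. That measured step exchanged a five-membered ring for a six-membered one, whereas compound 3 keeps a six-membered aromatic ring, so a step within the scatter is expected, a 2.0-fold higher number from compound 2 to compound 3 (0.30 log units; within the scatter). Compound 3 is estimated at 80 nM, between 20 nM and 400 nM.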

Compound 3, half-maximal inhibitory concentration: 330 nM
For compound 3 the middle estimate is 4.1-fold (0.62 log units) below the measured one, within the range that was stated.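

With the same atoms joined differently, pyridazin-4-yl in place of pyrimidin-5-yl does not pass unnoticed at this position: in this assay there is an 8.3-fold higher number from compound 2 to compound 3 (0.92 log units; beyond the scatter), so how the six-membered ring is arranged counts, not only that it is six-membered. Set against 1,3-oxazol-5-yl, pyridazin-4-yl still gives an at least 30-fold lower number from compound 1 to compound 3 (1.48 log units; beyond the scatter). Compound 1 enters that comparison only as a limit of the assay: the limit of > 10000 nM in this assay, at which 1 of the 3 values shown sits.

The compounds shown leave open how a plain phenyl ring or a pyridine ring would fare at this position. They also leave open whether an amine on the six-membered ring would change the picture.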